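This account rests on a few compounds, and the source may have more. Where it says the series, first, only, none or still open, it means among the compounds named here.

Compound 1 `Cc1c(O)ccc2c1[C@H](Cn1cc(-c3ccccc3)nn1)[C@@]13CC(=O)[C@@](C)(CC[C@@H]21)C3` gives > 20000 nM in a functional assay on A549 cells (Homo sapiens) for cytotoxicity, read by MTT assay, with a stated time of 4 days; on this read-out higher numbers stand for weaker inhibition and lower numbers for stronger inhibition.
Compound 2 `C=C1C[C@]23C[C@@]1(O)CC[C@H]2c1ccc(OS(=O)(=O)c2ccc(C)cc2)c(C)c1[C@@H]3Cn1cc(-c2ccc(Cl)cc2)nn1` gives > 20000 nM in this assay.
Compound 3 `Cc1c(O)ccc2c1[C@H](Cn1cc(-c3ccc(F)cc3)nn1)[C@@]13CC(=O)[C@@](C)(CC[C@@H]21)C3` gives > 20000 nM in this assay.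

Each of these values is a limit of the assay rather than a measured number. Compound 3 stands at the limit of > 20000 nM in this assay, at which 3 of the 3 values shown sit, so no order among the three compounds can be read. Compound 4 `Cc1c(O)ccc2c1[C@H](Cn1cc(-c3ccc(Cl)cc3)nn1)[C@@]13CC(=O)[C@@](C)(CC[C@@H]21)C3` differs from compound 3 in one place: chloro in place of fluoro on an aromatic carbon. For the measured compounds named here, the only measured step that resembles this change is a step that the two limits leave unreadable from compound 1 to compound 3, and that step cannot be sized either: both of its ends are limits. Going by the values given here, no measured step therefore gives a direction or a size for this change in this assay. Compound 4 is expected to remain at the limit, with an estimated value of 30000 nM and a range from 15000 nM to 80000 nM. The step that this estimate means is a step that the limit leaves unreadable from compound 3 to compound 4, expected to be none beyond the scatter.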

Compound 4, half-maximal inhibitory concentration: > 20000 nM
Compound 4 gave a limit, no number (the forecaster's own chance of this, stated with the estimate: 85%); the middle value lies beyond the limit too.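

The steps from compound 1 and compound 3 to compound 4 cannot be read, because both ends of each step are limits rather than numbers: the limit of > 20000 nM in this assay, at which 4 of the 4 values shown sit.

The compounds shown leave open how strongly any of them acts in this assay, and whether hydrogen, fluoro or chloro on that aromatic carbon makes any difference.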